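The source may hold more compounds than are shown below. What is called first, only, known or untested is meant among the compounds shown, and "the series" means these compounds.

Compound 1 `Cc1cc2c(C(C)C)ccc(C)c2cc1OC(=O)c1cccc(C(F)(F)F)c1` is an ester of the shared core carrying a trifluoromethyl group on the benzoate ring, and in a functional assay on HCT-15 cells (Homo sapiens) for antiproliferative activity, read by sulforhodamine B assay, with a stated time of 48 h, tested at 50 uM (a higher number here means more inhibition at the concentration tested (going by the name of the read-out), a lower number less inhibition), compound 1 is recorded as "not active" (no number reported), so no number marks where it stands. Within the data shown here, its positional isomer compound 2 `Cc1cc2c(C(C)C)ccc(C)c2cc1OC(=O)c1ccc(C(F)(F)F)cc1` is the only compound with a figure: in this assay compound 2 gives 55.6%. Among the measured compounds shown here, no step between compound 1 and compound 2 has been worked out, and the two results show only that one isomer was reported as not active while the other has a number for its inhibition.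

Compound 3 `COc1cccc(C(=O)Oc2cc3c(C)ccc(C(C)C)c3cc2C)c1` is the yet unmeasured partner of compound 1, differing by methoxy in place of trifluoromethyl on an aromatic carbon. For the measured compounds named here, with no measured step of this kind to lean on, the size and direction of the change in this assay remain open. Compound 3 is expected to give a low inhibition number, near 15%, within a range from 0% to 45%.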

Compound 3, a percentage reported as inhibition, at one concentration (the size of the read-out at that concentration, not a potency): 35.2%
The estimate for compound 3 lay 20.2 percentage points below the measured number; low and high end bracket the measured number.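

In this assay no step can be read between compound 1 and compound 3, as only compound 3 carries a number. The compounds shown leave open what replacing trifluoromethyl with methoxy does to inhibition, and no measured evidence bears on this result.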